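Fluoro for hydroxy on the saturated ring of compound 2

A few compounds are considered here, and "the series" means these few. Any claim that something is new, unique, unknown or untested is made for them only; others in the source may bear on it.

Measured compounds in an ADME assay on MDCK cells (Canis lupus familiaris) for cytotoxicity, read by MTT assay, with a stated time of 48 h; on this read-out lower numbers stand for higher toxicity in this test and higher numbers for lower toxicity in this test:
compound 1 `COc1ccc([C@H]2CC(C)(O)[C@@H]3CC[C@@H](C)C[C@H]3O2)c(OC)c1`, > 937000 nM
compound 2 `COc1cc(OC)c([C@H]2CC(C)(O)[C@@H]3CC[C@@H](C)C[C@H]3O2)c(OC)c1`, 856000 nM
compound 3 `C[C@@H]1CC[C@@H]2[C@@H](C1)O[C@@H](c1ccc([N+](=O)[O-])cc1)CC2(C)O`, > 982000 nM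

For the measured compounds named here, compound 2 is the only compound of the three with a number in this assay. For compound 1 the value > 937000 nM is a limit of the assay, not a number. For compound 3 the value > 982000 nM is likewise a limit. Going by the values given here, the one measured step, methoxy in place of hydrogen on an aromatic carbon, gives an at least 1.0-fold lower number from compound 1 to compound 2 (0.03 log units; that floor lies within the scatter), which lies within the scatter.

Compound 4 `COc1cc(OC)c([C@H]2CC(C)(F)[C@@H]3CC[C@@H](C)C[C@H]3O2)c(OC)c1` differs from compound 2 by fluoro in place of hydroxy on a saturated ring carbon. No measured step touches this saturated ring carbon; the only step shown lies on the aromatic ring and stays within the scatter, while compound 1 and compound 3 sit at limits. The account therefore expects no step beyond the scatter, a 1.0-fold lower number from compound 2 to compound 4 (0.00 log units; within the scatter). Compound 4 is estimated at 850000 nM, between 400000 nM and 1000000 nM.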

Compound 4, half-maximal cytotoxic concentration: 851000 nM
For compound 4 the middle estimate is 1.0-fold (0.00 log units) below the measured one; the measured number falls inside the stated range.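

In this assay, the only step shown away from the aromatic ring is this one on a saturated ring carbon, and fluoro in place of hydroxy gives a 1.0-fold lower number from compound 2 to compound 4 (0.00 log units; within the scatter) in this read-out. Hydroxy, with 1 hydrogen-bond donor and 1 hydrogen-bond acceptor, thus gives way to fluoro, with 0 of each, with no shift beyond the scatter, and compound 4, like compound 2, gives a number and not a limit. Nothing measured here accounts for this step.

The compounds shown leave open how an amine or a carboxylic acid would read on this saturated ring carbon, and whether a longer chain there would also stay within the scatter. They also leave open how fluoro in place of hydroxy would read on compound 1 or compound 3, whose values are limits of the assay.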